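This account rests on a few compounds, and the source may have more. Where it says the series, first, only, none or still open, it means among the compounds named here.

Compound 1 `Cc1ccccc1-c1nn2c(Cn3nnc4ccccc43)nnc2s1`: 55%
Compound 2 `Cc1cccc(OCc2nn3c(Cn4nnc5ccccc54)nnc3s2)c1`: 50%
Compound 3 `CCc1nnc2sc(-c3cccc(F)c3)nn12`: 13%

In an assay for inhibition of histone-lysine N-methyltransferase, H3 lysine-79 specific (Homo sapiens), with stated times of 15 min and 120 min, tested at 50 uM (on this read-out higher numbers stand for more inhibition at the one concentration tested (going by the name of the read-out) and lower numbers for less inhibition), compound 3 gives 13%, the lowest of the three numbers, beyond the scatter below both compound 2 and compound 1. Among the measured compounds shown here, the only single-change step measured, a number 5 percentage points lower from compound 1 to compound 2 (within the scatter), alters a group on an aromatic carbon and stays within the scatter, so it says nothing about the saturated chain carbon. Compound 4 `Fc1cccc(-c2nn3c(Cc4ccccc4F)nnc3s2)c1` differs from compound 3 by 2-fluorophenyl in place of methyl on a saturated chain carbon bound to an aromatic carbon. For the measured compounds named here, compounds 1 and 2 differ from compound 3 in more than one place, so no step links them to it. Going by the values given here, with no directly comparable step, compound 4 is expected to rise by a number 22 percentage points higher from compound 3 to compound 4 (beyond the scatter), with wide uncertainty. Compound 4 is therefore estimated at 35%, between 8% and 62%.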

Compound 4, a percentage reported as inhibition, at one concentration (the size of the read-out at that concentration, not a potency): 25%
Compound 4: middle estimate off by 10 percentage points, on the high side; low and high end bracket the measured number.
By their numbers in this assay, from the lowest: compound 3; then compound 4; then compounds 2 and 1 (each within the scatter of the next).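

In this assay, among the compounds shown here, this is the first measured change on the saturated chain carbon bound to an aromatic carbon: with 2-fluorophenyl in place of methyl, there is a number 12 percentage points higher from compound 3 to compound 4 (beyond the scatter). The carbon therefore accepts a six-membered aromatic ring with a modest gain in inhibition. Nothing measured here explains the rise.

Going by these compounds, it remains open whether the ring or its fluorine carries the gain, and how plain phenyl would compare. On these data alone, how an amine or a carboxylic acid would fare at this position is also open.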